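Nitro for Cyano on a Rearranged Anilide Core

The compounds below may be only part of what the source reports. "The series", "measured", "known", "first", "only" and "open" are said of these compounds alone.

Three compounds have been measured in a functional assay on LNCaP cells (Homo sapiens) for antiproliferative activity, read by propidium iodide staining, with a stated time of 96 h; on this read-out higher numbers stand for weaker inhibition and lower numbers for stronger inhibition:

Compound 1, `CC(O)(CSc1ccc(S(F)(F)(F)(F)F)cc1)C(=O)Nc1ccc(C#N)c(C(F)(F)F)c1`: 16900 nM
Compound 2, `CC(O)(CSc1ccc(S(F)(F)(F)(F)F)cc1)C(=O)Nc1ccc([N+](=O)[O-])c(C(F)(F)F)c1`: 8700 nM
Compound 3, `CC(O)(CSc1ccc(S(F)(F)(F)(F)F)cc1)C(=O)Nc1ccc(C#N)cc1C(F)(F)F`: 15100 nM

Compound 1 and compound 2 share one core and differ in a single place, (nitro in place of cyano on an aromatic carbon). That change gave a 1.9-fold lower number from compound 1 to compound 2 (0.29 log units; within the scatter). Compound 3 has the same atoms as compound 1 joined differently; the difference between the two cores is not broken down here. In this assay compound 3 and compound 1 give numbers that lie within the scatter of each other.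

Compound 4, `CC(O)(CSc1ccc(S(F)(F)(F)(F)F)cc1)C(=O)Nc1ccc([N+](=O)[O-])cc1C(F)(F)F`, has not yet been measured. It stands to compound 3 as compound 2 stands to compound 1: nitro in place of cyano on an aromatic carbon. The surroundings are not identical, since in compound 1 the group sits ortho to a trifluoromethyl group while in compound 3 it sits meta to it, so this is the same kind of change rather than the same change. Because the earlier step was a 1.9-fold lower number from compound 1 to compound 2 (0.29 log units; within the scatter), a step of about the same size is expected from compound 3 to compound 4, a 1.8-fold lower number from compound 3 to compound 4 (0.25 log units; within the scatter). For compound 4 the expected value in this assay is 8500 nM, estimated between 3500 nM and 20000 nM.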

Compound 4, half-maximal inhibitory concentration: 10300 nM
Beside the measured number, compound 4's estimate is 1.2-fold (0.08 log units) below it, within the range that was stated.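

On the core of compound 3, nitro in place of cyano gave a 1.5-fold lower number from compound 3 to compound 4 (0.17 log units; within the scatter) in this assay. Set beside the same swap on the core of compound 1, the two steps agree as closely as repeated measurements would be expected to: the same change on two cores in this assay, a 1.9-fold lower number (0.29 log units; within the scatter) from compound 1 to compound 2 and a 1.5-fold lower number (0.17 log units; within the scatter) from compound 3 to compound 4, 1.3-fold (0.12 log units) apart, within the scatter of two such steps. The swap therefore behaves alike on these two cores, but each step lies within the scatter, so the data do not show that nitro truly differs from cyano on either core, and two cores cannot speak for the whole series.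

The compounds shown leave open whether another group in the same place, such as an amine or a carboxylic acid, would shift the number beyond the scatter. They also leave open whether nitro and cyano would stay this close on a core that carries no trifluoromethyl group.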